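A few compounds are considered here, and "the series" means these few. Any claim that something is new, unique, unknown or untested is made for them only; others in the source may bear on it.

Measured compounds:
- compound 1, `CCC(=O)N(Cc1ccc(OC)c(O)c1)c1cc(OC)c(OC)c(OC)c1`: 50 nM
- compound 2, `C/C=C/C(=O)N(Cc1ccc(OC)c(Br)c1)c1cc(OC)c(OC)c(OC)c1`: 6430 nM
- compound 3, `COc1ccc(CNc2cc(OC)c(OC)c(OC)c2)cc1F`: 39700 nM

All three numbers come from a functional assay on MGC-803 cells (Homo sapiens) for inhibition, read by MTT assay, with a stated time of 48 h; a higher number here means a weaker inhibitor, a lower number a stronger inhibitor. Compound 1 stands lowest of the three; the nearest is compound 2, whose number lies beyond the scatter above it, and compound 3 lies further still, also beyond the scatter. Compound 1 differs from compound 2 and from compound 3 in more than one place, so those gaps are not read as single steps; they only show where compound 1 sits relative to the rest of the set.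

The next compound is compound 4, `COc1ccc(CN(C(=O)C(C)Br)c2cc(OC)c(OC)c(OC)c2)cc1O`, which differs from compound 1 in one place: bromo in place of hydrogen on a saturated chain carbon bound to a carbonyl carbon and a saturated chain carbon. Put the other way, propanoyl in compound 1 becomes (1-bromoethyl)carbonyl in compound 4, and the bromine is the only heavy atom added.

Among the measured compounds shown here, no measured pair in this set changes at that place, so there is nothing here to size the step against. The expectation is a small step, if any, likely no larger than the usual scatter, with a slight lean toward a higher number for compound 4. On that basis compound 4 is estimated at 100 nM in this assay, with a range of 25 nM to 500 nM; this estimate means a step of a 2.0-fold higher number from compound 1 to compound 4 (0.30 log units; within the scatter).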

Compound 4, half-maximal inhibitory concentration: 120 nM
Compound 4: middle estimate off by 1.2-fold (0.08 log units), on the low side; the measured number falls inside the stated range.
By their numbers in this assay, from the lowest: compound 1; then compound 4; then compound 2; then compound 3.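

In this assay, the set gains its first comparison of compounds that differ in one place: bromo in place of hydrogen on a saturated chain carbon bound to a carbonyl carbon and a saturated chain carbon gives a 2.4-fold higher number from compound 1 to compound 4 (0.38 log units; beyond the scatter), a modest step. Among the compounds shown here, this places a first measured size on a change at this carbon, where the earlier compounds offered no single-place comparison, and shows that adding 1 bromine to the propanoyl group shifts the number only modestly, with compound 4 at 120 nM. No supporting measurement is available to account for the step, so its origin remains unassigned.

A single substitution cannot show whether the step is specific to bromo or would also appear with fluoro, chloro, methyl, hydroxyl or an amine on the same carbon. It also leaves open how a longer chain in place of the propanoyl group would read in this assay, and whether the bromo step would keep its size on a compound that differs elsewhere from compound 1.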